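Chloro on the Benzyl Ring of Compound 3

A few compounds are considered here, and "the series" means these few. Any claim that something is new, unique, unknown or untested is made for them only; others in the source may bear on it.

Compound 3 `O=C1c2ccccc2N(Cc2ccccc2)S(=O)(=O)N1Cc1ccccc1` gives 66000 nM in a functional assay on MRC5 cells (Homo sapiens) (on this read-out higher numbers stand for lower toxicity in this test and lower numbers for higher toxicity in this test), and stands highest of the two numbers at hand. Compound 1 `N#Cc1ccc(CN2c3ccccc3C(=O)N(Cc3ccccc3)S2(=O)=O)cc1` gives 62000 nM in this assay, and the step of a 1.1-fold higher number from compound 1 to compound 3 (0.03 log units; within the scatter) is within the scatter. Compound 2 `O=C1c2ccccc2N(Cc2ccccc2-c2ccccc2)S(=O)(=O)N1Cc1ccccc1` gives only a limit in this assay, namely > 55000 nM. Because of the limit of > 55000 nM in this assay, at which 1 of the 3 values shown sits, the step that the limit leaves unreadable from compound 2 to compound 3 cannot be read. Compound 4 `O=C1c2ccccc2N(Cc2ccccc2Cl)S(=O)(=O)N1Cc1ccccc1` carries the change (chloro in place of hydrogen on an aromatic carbon). Both measured steps alter the same benzyl ring of the shared core, and the one that can be read, from the nitrile-bearing compound 1 to compound 3, is within the scatter; the other is hidden by the limit. Among the compounds with values here, no measured step bears on chloro itself. He therefore expects the step of a 1.1-fold lower number from compound 3 to compound 4 (0.04 log units; within the scatter) to stay within the scatter. Compound 4 is expected to give about 60000 nM in this assay. Its likely range is estimated to run from 30000 nM to 120000 nM.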

Compound 4, half-maximal cytotoxic concentration: 60000 nM
Estimate against measurement, compound 4: no gap at the digits printed; the range from low to high includes it.
By their numbers in this assay, from the lowest: compounds 4, 1 and 3 (each within the scatter of the next).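

In this assay, chloro on an aromatic carbon ortho to a large group now has a measured step of its own, and a 1.1-fold lower number from compound 3 to compound 4 (0.04 log units; within the scatter) shows that benzyl and 2-chlorobenzyl cannot be told apart at this place. The step of a 1.0-fold lower number from compound 1 to compound 4 (0.01 log units; within the scatter) adds that 2-chlorophenyl and 4-cyanophenyl cannot be told apart here either, so hydrogen, chloro and nitrile, the three readable variations on this benzyl ring, all lie within the scatter of one another. The steps from compound 2, whose value is a limit, cannot be read: the limit of > 55000 nM in this assay, at which 1 of the 4 values shown sits.

The compounds shown leave open whether an amine or a carboxylic acid on this ring would give a step beyond the scatter. They also leave open what chloro would do on the other benzyl group of the shared core.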